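Aryl in place of isobutyl on the azole nitrogen

The source may hold more compounds than are shown below. What is called first, only, known or untested is meant among the compounds shown, and "the series" means these compounds.

Measured so far:
- compound 1, `COc1cc(-c2nccn2CC(C)C)cc(OC)c1OC`: > 100000 nM (a limit)
- compound 2, `COc1cc(-c2nccn2-c2ccc3sccc3c2)cc(OC)c1OC`: 400 nM

Compound 1 stands at the weak end of what has been measured. In a functional assay on MDA-MB-468 cells (Homo sapiens) for antiproliferative activity, read by MTT assay, with a stated time of 72 h (a higher number here means a weaker inhibitor, a lower number a stronger inhibitor), compound 1 gives only a limit, > 100000 nM, so no number is known for it. Among the measured compounds shown here, the only value at this limit is that of compound 1, which sits at the limit of > 100000 nM in this assay, at which 1 of the 2 values shown sits. Compound 2, which carries a ring group on the same aromatic nitrogen of the shared core, reaches 400 nM in this assay; the two compounds differ in more than one place, so their values are simply placed side by side.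

Compound 3, `COc1ccc(-n2ccnc2-c2cc(OC)c(OC)c(OC)c2)cc1`, is not yet measured. It differs from compound 1 by 4-methoxyphenyl in place of isobutyl on an aromatic nitrogen. Because compound 2 carries a ring group on the same aromatic nitrogen and gives 400 nM in this assay, a step toward stronger inhibition, well beyond the scatter, is expected for compound 3. The expected step from compound 1 to compound 3 is an at least 66-fold lower number from compound 1 to compound 3 (1.82 log units; beyond the scatter). For compound 3 the estimate in this assay is 1500 nM, with a range from 200 nM to 15000 nM.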

Compound 3, half-maximal inhibitory concentration: 500 nM
The estimate for compound 3 lay 3.0-fold (0.48 log units) above the measured number; measured number inside the range.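

In this assay, among the compounds shown here, the change from isobutyl to 4-methoxyphenyl on the aromatic nitrogen of the shared core is the first comparison that alters one place only, and it gives an at least 200-fold lower number from compound 1 to compound 3 (2.30 log units; beyond the scatter). On these data alone, the true size of this step stays unknown, because compound 1 gives only a limit and not a number: the limit of > 100000 nM in this assay, at which 1 of the 3 values shown sits. Compound 3, with one six-membered aromatic ring of carbon only on this nitrogen, gives 500 nM, so measurable activity with a ring group here is not confined to compound 2.

As far as these compounds go, what a plain phenyl or a longer chain ending in an amine would give on this nitrogen remains open, so the step cannot yet be divided between the ring and its methoxy group. Also open, from the compounds shown here alone, is whether a step of this kind would hold on a different core or in a different cell line.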